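The source may hold more compounds than are shown below. What is called first, only, known or untested is meant among the compounds shown, and "the series" means these compounds.

Measured so far in an assay on HEK293 cells for agonist activity at Toll-like receptor 8 (Homo sapiens), read by a luciferase reporter, with a stated time of 6 h; a higher number here means that more compound is needed for the effect, a lower number that less compound is needed:
compound 1 `CCCCNc1nc(N)nc2c1CN(C(C)=O)CC2` gives 0.5 uM
compound 2 `CCCCNc1nc(N)nc2c1CN(Cc1c(Cl)cccc1Cl)CC2` gives 0.14 uM
compound 3 `CCCCNc1nc(N)nc2c1CN(Cc1cc(F)cc(F)c1)CC2` gives 0.23 uM

Compound 3 holds the second highest of these three numbers. Its nearest neighbour is compound 2, within the scatter; compound 1 lies furthest, with a higher number, beyond the scatter. Compound 4 `CCCCNc1nc(N)nc2c1CN(Cc1cccnc1)CC2` differs from compound 3 in one place: pyridin-3-yl in place of 3,5-difluorophenyl on a saturated chain carbon bound to an amine nitrogen in a ring. Among the measured compounds shown here, the only measured step at this place is a 1.6-fold higher number from compound 2 to compound 3 (0.22 log units; within the scatter), an exchange of one six-membered aromatic ring for another that stayed within the scatter. A further ring exchange at the same place is therefore expected to give a step of about a 1.3-fold higher number from compound 3 to compound 4 (0.12 log units; within the scatter), not beyond the scatter. Compound 4 is thus expected to give roughly 0.3 uM, estimated between 0.12 uM and 0.8 uM.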

Compound 4, minimum effective concentration: 0.13 uM
Beside the measured number, compound 4's estimate is 2.3-fold (0.36 log units) above it; the range from low to high includes it.
By their numbers in this assay, from the lowest: compounds 4, 2 and 3 (each within the scatter of the next); then compound 1.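

In this assay, a ring nitrogen is tolerated at this place: a 1.8-fold lower number from compound 3 to compound 4 (0.25 log units; within the scatter) and a 1.1-fold lower number from compound 2 to compound 4 (0.03 log units; within the scatter) both stay within the scatter, so the three aromatic rings cannot be told apart here. Putting (pyridin-3-yl)methyl in place of acetyl gives a 3.8-fold lower number from compound 1 to compound 4 (0.59 log units; beyond the scatter), a modest step beyond the scatter. Nothing available explains these numbers.

The compounds shown leave open whether an aromatic ring is needed on this chain carbon at all, which a saturated ring such as cyclohexyl could test. They also leave open whether the ring nitrogen's location matters, as pyridin-2-yl or pyridin-4-yl could show.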